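The compounds below may be only part of what the source reports. "The series", "measured", "known", "first", "only" and "open" are said of these compounds alone.

Measured compounds:
- compound 1 `CCCc1cc(NC)c2cc(NC(=O)/C=C/c3ccc(C(F)(F)F)cc3)ccc2n1` gives 1.5 nM in an assay on isolated protein for displacement of a labelled ligand from melanin-concentrating hormone receptor 1 (Homo sapiens); a lower number here means a stronger inhibitor, a higher number a weaker inhibitor
- compound 2 `CCCc1cc(N)c2cc(NC(=O)CCc3ccccc3)ccc2n1` gives 8300 nM in this assay
- compound 3 `CCCc1cc(N)c2cc(NC(=O)C3CCC(c4ccc(Cl)cc4)CC3)ccc2n1` gives 4.4 nM in this assay

Compound 1 has the lowest number of the three. Compound 3 comes nearest to it, and compound 2 stands farthest off; both gaps lie beyond the usual scatter. Compound 4 `CCCc1cc(NC2CCC2)c2cc(NC(=O)/C=C/c3ccc(C(F)(F)F)cc3)ccc2n1` has not yet been measured. It differs from compound 1 in one place: cyclobutyl in place of methyl on a nitrogen on an aromatic ring. Among the compounds with values here, no measured pair shows a change of this kind, so the size of the step cannot be read from the data and can only be expected. The step is expected to be small, toward a somewhat higher number, near the edge of the scatter a 2.0-fold higher number from compound 1 to compound 4 (0.30 log units; within the scatter). For compound 4 the estimate is 3 nM, with a range from 1 nM to 15 nM.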

Compound 4, half-maximal inhibitory concentration: 18 nM
The estimate for compound 4 lay 6.0-fold (0.78 log units) below the measured number; the whole stated range lies below it.
By their numbers in this assay, from the lowest: compound 1; then compound 3; then compound 4; then compound 2.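

In this assay, within the data shown here, cyclobutyl in place of methyl on a nitrogen on an aromatic ring gives a 12-fold higher number from compound 1 to compound 4 (1.08 log units; beyond the scatter), the first measured change at this place, and it lies beyond the scatter. Even so, compound 4 stays at 18 nM, so a four-membered ring of carbon here does not abolish activity. Nothing at hand accounts for the size of this step.

From the compounds shown here alone, how the number moves with ethyl or cyclopropyl on this nitrogen remains open. So does whether the step would be the same with the amide of compound 3.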